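Fluorine on the benzyl ring of a nitro chalcone

The compounds below may be only part of what the source reports. "The series", "measured", "known", "first", "only" and "open" are said of these compounds alone.

Compound 3 `O=C(/C=C/c1ccc(OCc2cn(Cc3ccccc3)nn2)cc1)c1ccc([N+](=O)[O-])cc1` was tested in a functional assay on HepG2 cells (Homo sapiens) for inhibition, read by MTT assay, with a stated time of 48 h, tested at 10 uM (on this read-out higher numbers stand for more inhibition of growth at the one concentration tested and lower numbers for less inhibition of growth), and came out as "not active" (no number reported), so no number stands for it. Compound 4 `O=C(/C=C/c1ccc(OCc2cn(Cc3ccccc3F)nn2)cc1)c1ccc([N+](=O)[O-])cc1` differs from it by one change, (fluoro in place of hydrogen on an aromatic carbon), with the rest of the molecule unchanged. The same change has been measured once in a related pair: compound 1 `COc1ccc(C(=O)/C=C/c2ccc(OCc3cn(Cc4ccccc4)nn3)cc2)cc1` gives 51% in this assay, compound 2 `COc1ccc(C(=O)/C=C/c2ccc(OCc3cn(Cc4ccccc4F)nn3)cc2)cc1` gives 33%, and the change a number 18 percentage points lower from compound 1 to compound 2 (beyond the scatter). Nothing in those two compounds suggests that adding the fluorine raises growth inhibition, and compound 3 starts from no measurable activity. Compound 4 is therefore expected to stay inactive or near it, with an estimated 10% in this assay, ranging from 0% to 30%.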

Compound 4, percent growth inhibition at one concentration: 22%
Estimate against measurement, compound 4: 12 percentage points below; measured number inside the range.
By their numbers in this assay, from the lowest: compound 4; then compound 2; then compound 1.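

In this assay the nitro series gains a number with the 2-fluorobenzyl group: compound 3 reads "not active" (no number reported), while compound 4 reads 22%, so fluoro in place of hydrogen does not go with a loss here as it does from compound 1 to compound 2. With the 2-fluorobenzyl group kept, nitro in place of methoxy gives a number 11 percentage points lower from compound 2 to compound 4 (beyond the scatter). No measurement shown gives a reason for either result. Going by these compounds, whether chloro or an amine in place of the fluoro would also give a measurable number stays open.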